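Terminal amine exchange on the aminoethyl chain

The source may report more compounds than this note shows. Statements on the series, on what has been measured and on what is new or still open speak of the compounds shown alone.

Compound 3 `CN1CCN(CCN(C)c2ccc(Cn3c(=O)[nH]c4c(N)nc(C(F)(F)F)cc43)cn2)CC1` stands level with compound 1 `CN(CCN1CCCCC1)c1ccc(Cn2c(=O)[nH]c3c(N)nc(C(F)(F)F)cc32)cn1`, the two together the highest of the three numbers in an in vitro ADME assay on microsomes from liver (Homo sapiens) for pharmacokinetics; a higher number here means faster removal of the compound, a lower number slower removal: compound 3 gives 25 mL.min-1.g-1 and compound 1 gives 25 mL.min-1.g-1. Compound 2 `Nc1nc(C(F)(F)F)cc2c1[nH]c(=O)n2Cc1ccc(NCCN2CCCC2)nc1` gives 8.5 mL.min-1.g-1, the separation being a 2.9-fold higher number from compound 2 to compound 3 (0.47 log units; beyond the scatter). Compound 4 `CN(C)CCN(C)c1ccc(Cn2c(=O)[nH]c3c(N)nc(C(F)(F)F)cc32)cn1` carries dimethylamino in place of 4-methylpiperazin-1-yl on a saturated chain carbon, two bonds along the chain from a nitrogen on an aromatic ring. Going by the values given here, the closest precedent is the exchange of ring amines at the same place, no change at the digits printed from compound 1 to compound 3 (within the scatter); the route toward compound 2 alters two things at once and reads a 2.9-fold lower number from compound 1 to compound 2 (0.47 log units; beyond the scatter). In the one comparable case, altering only the chain terminus left this assay unmoved, so compound 4 is expected to show a 1.3-fold lower number from compound 3 to compound 4 (0.10 log units; within the scatter). The estimate for compound 4 is 20 mL.min-1.g-1, within 8 mL.min-1.g-1 to 50 mL.min-1.g-1.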

Compound 4, intrinsic clearance in microsomes: 16 mL.min-1.g-1
Compound 4: the middle estimate sits 1.3-fold (0.10 log units) above what was measured, within the range that was stated.
By their numbers in this assay, from the lowest: compounds 2, 4, 1 and 3 (each within the scatter of the next, the first and the last beyond it).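

In this assay, the dimethylamino group at this saturated chain carbon gives a 1.6-fold lower number from compound 3 to compound 4 (0.19 log units; within the scatter) and a 1.6-fold lower number from compound 1 to compound 4 (0.19 log units; within the scatter), so neither ring amine is separated from the open-chain terminus. The step of a 1.9-fold higher number from compound 2 to compound 4 (0.27 log units; within the scatter) also stays inside the scatter, although compound 2 is beyond it from compound 1 and compound 3. No measurement here offers a cause for these readings.

The methyl(2-(pyrrolidin-1-yl)ethyl)amino group would separate the pyrrolidin-1-yl terminus from the other change in compound 2. A morpholin-4-yl terminus remains an open test at this chain carbon.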